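A few compounds are considered here, and "the series" means these few. Any claim that something is new, unique, unknown or untested is made for them only; others in the source may bear on it.

Measured so far:
compound 1 `O=C(c1ccccc1)N1CCn2nc(-c3cccnc3)cc2C1`: > 10000 nM
compound 2 `O=C(c1ccccc1Cl)N1CCn2nc(-c3ccccn3)cc2C1`: 2480 nM

In a functional assay on HEK293 cells for negative allosteric modulation of metabotropic glutamate receptor 5 (Homo sapiens), read by calcium flux, with a stated time of 20 min (a lower number here means a stronger inhibitor, a higher number a weaker inhibitor), compound 2 gives 2480 nM, the only real number among the two results shown. Compound 1 reaches only a limit of the assay, > 10000 nM, not a number (the limit of > 10000 nM in this assay, at which 1 of the 2 values shown sits). Compound 3 `O=C(c1cccc(Cl)c1)N1CCn2nc(-c3ccccn3)cc2C1` differs from compound 2 by 3-chlorophenyl in place of 2-chlorophenyl on a carbonyl carbon. Among the compounds with values here, no measured pair shows how such a change affects the outcome in this assay, so only a modest shift is expected, and its direction is uncertain. Compound 3 is therefore expected to give about 1500 nM, with a likely range from 300 nM to 8000 nM. The expected step is a 1.7-fold lower number from compound 2 to compound 3 (0.22 log units; within the scatter).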

Compound 3, half-maximal inhibitory concentration: 176 nM
The estimate for compound 3 lay 8.5-fold (0.93 log units) above the measured number, and the stated range ends above it.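

Putting 3-chlorophenyl in place of 2-chlorophenyl on the carbonyl carbon gives a 14-fold lower number from compound 2 to compound 3 (1.15 log units; beyond the scatter) in this assay. The place of the chlorine on this phenyl group therefore matters greatly, even though the two compounds have the same atoms; compound 1 and compound 2 differ in more than one place and could not show this. Nothing measured here explains the size of this step. Still open, as far as these compounds go, is how a methoxy or a nitrile group would fare in place of the chlorine.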